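An Amino Group in Place of Cyano

The source may hold more compounds than are shown below. What is called first, only, known or untested is meant among the compounds shown, and "the series" means these compounds.

For the measured compounds named here, in a functional assay on MV4-11 cells (Homo sapiens) for antiproliferative activity, read by MTT assay (a higher number here means a weaker inhibitor of growth, a lower number a stronger inhibitor of growth), compound 1 (`COc1ccc(Nc2nc(NC3CCCC3)c3ccccc3n2)cc1`) gives 4910 nM as the only number so far. Compound 2 (`N#Cc1ccc(Nc2nc(NC3CCCC3)c3ccccc3n2)cc1`) stands without a value: its entry reads "not determined" (no result reported) and so offers no starting point of its own. The next compound to be measured is compound 3 (`Nc1ccc(Nc2nc(NC3CCCC3)c3ccccc3n2)cc1`). The structural change is amino in place of cyano on an aromatic carbon with amino in place of cyano on an aromatic carbon, para to a large group. Going by the values given here, no measured pair shows what such a change does in this assay and compound 2 has no number, so no direction can be argued from it. Among the compounds with values here, the only guide is compound 1 at 4910 nM and against that value no step beyond the usual scatter is expected. For compound 3 the expected value is 3500 nM with an estimated range from 900 nM to 12000 nM in this measurement.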

Compound 3, concentration for 50% growth inhibition: 4420 nM
For compound 3 the middle estimate is 1.3-fold (0.10 log units) below the measured one, within the range that was stated.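

In this assay the position para to a large group now has its first readable step: amino in place of methoxy on the aromatic carbon gives a 1.1-fold lower number from compound 1 to compound 3 (0.05 log units; within the scatter) and so the two groups cannot be told apart at this position in this measurement. As far as these compounds go, compound 2 has no number, so the step from cyano to amino that leads to compound 3 cannot be read, and the effect of that change remains unknown. Nothing measured here accounts for the closeness of compound 1 and compound 3.

The compounds shown leave open whether a carboxylic acid, a longer chain such as butoxy, or a halogen such as chlorine at this position would move the number beyond the scatter. They also leave open whether a change elsewhere on the shared core would do so.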